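A Single Inverted Stereocentre and Its Expected Cost

The source may report more compounds than this note shows. Statements on the series, on what has been measured and on what is new or still open speak of the compounds shown alone.

In a functional assay on A549 cells (Homo sapiens) for cytotoxicity, read by MTT assay (on this read-out higher numbers stand for weaker inhibition and lower numbers for stronger inhibition), compound 3 (`COC(=O)C[C@H]1C[C@@H](O)[C@@H](C)[C@@H](c2ccc(OC)cc2)N1`) gives 23500 nM as the lowest of the two numbers available. Compound 1 (`COC(=O)C[C@H]1C[C@H](O)[C@@H](C)[C@@H](c2ccc(C)cc2)N1`) gives 97600 nM as a higher number, beyond the scatter, and compound 2 (`COC(=O)C[C@H]1C[C@H](O)[C@@H](C)[C@@H](c2ccc(C(C)C)cc2)N1`) stands as "not active" (no number reported) with no number reported. Compound 4 (`COC(=O)C[C@H]1C[C@H](O)[C@@H](C)[C@@H](c2ccc(OC)cc2)N1`) has not yet been measured. It departs from compound 3 by the two compounds have the same atoms and bonds and differ only in configuration as drawn: 1 of 4 stereo elements differ; a stereocentre at a saturated ring carbon is drawn R in compound 3 and S in compound 4 in that a stereocentre at a saturated ring carbon is drawn R in compound 3 and S in compound 4. For the measured compounds named here, compound 4 shares that drawn configuration with compound 1 and compound 2, so weaker inhibition seems likely, though compound 1 at 97600 nM is the only number to go on. The expected change is a 2.6-fold higher number from compound 3 to compound 4 (0.41 log units; beyond the scatter) in this assay and points toward a higher number. For compound 4 the estimated value is 60000 nM with an expected range of 20000 nM to 180000 nM in this measurement.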

Compound 4, half-maximal inhibitory concentration: 5400 nM
The estimate for compound 4 lay 11-fold (1.05 log units) above the measured number; the measured number lies below the stated range.
By their numbers in this assay, from the lowest: compound 4; then compound 3; then compound 1.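

In this assay, the S configuration at the saturated ring carbon, shared with compound 1 and compound 2, goes with stronger inhibition, with a 4.4-fold lower number from compound 3 to compound 4 (0.64 log units; beyond the scatter). The change belongs to that stereocentre alone because nothing else separates the pair: the fact that compounds 3 and 4 differ only in the configuration as drawn. With that configuration held, methoxy in place of methyl on an aromatic carbon gives an 18-fold lower number from compound 1 to compound 4 (1.26 log units; beyond the scatter).

On these data alone, what a carboxylic acid in place of the methyl ester, or a chlorine in place of the methoxy, would do stays open. So does whether the same inversion shifts the number with methyl on the aromatic carbon.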